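The source may report more compounds than this note shows. Statements on the series, on what has been measured and on what is new or still open speak of the compounds shown alone.

The series examined on a functional assay on HaCaT cells (Homo sapiens) for inhibition, read by sulforhodamine B assay, with a stated time of 48 h (a lower number here means a stronger inhibitor of growth, a higher number a weaker inhibitor of growth), begins with compound 1, whose structure is `COc1ccc(/C=C/C2(C)C=CC(=O)O2)c(OC)c1OC`; in this assay compound 1 gives 217000 nM. Compound 2, built as `COc1c(O)ccc(/C=C/C2(C)C=CC(=O)O2)c1OC`, gives 64400 nM in this assay. Compound 3, built as `CC1(/C=C/c2cccc(O)c2)C=CC(=O)O1`, gives 88100 nM in this assay, a number within the usual scatter of that of compound 2 and beyond it relative to compound 1. The difference between the cores of compound 2 and compound 3 is not broken down here.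

Between compound 2 and compound 1 the change is methyl in place of hydrogen on an oxygen on an aromatic ring, and it made the step of a 3.4-fold higher number from compound 2 to compound 1 (0.53 log units; beyond the scatter), a modest weakening of growth inhibition that lies beyond the scatter.

Compound 4, built as `COc1cccc(/C=C/C2(C)C=CC(=O)O2)c1`, has not yet been measured in this assay. It differs from compound 3 by methyl in place of hydrogen on an oxygen on an aromatic ring, the same change, on an oxygen on an aromatic ring whose other neighbours are aromatic carbon, as that from compound 2 to compound 1. Because that change gave a 3.4-fold higher number from compound 2 to compound 1 (0.53 log units; beyond the scatter), the step for compound 4 is expected to be of a like size and direction, roughly a 3.0-fold higher number from compound 3 to compound 4 (0.47 log units; beyond the scatter). Resting on the single measured instance of this change, compound 4 is estimated to give 260000 nM in this assay, with a range from 110000 nM to 620000 nM expected to hold the measured number.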

Compound 4, concentration for total growth inhibition: 5700 nM
Beside the measured number, compound 4's estimate is 46-fold (1.66 log units) above it; measured number below the stated range.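

In this assay, the change from hydroxy to methoxy did not carry over from one core to the other, and the two steps run in opposite directions: the same change on two cores in this assay, a 3.4-fold higher number (0.53 log units; beyond the scatter) from compound 2 to compound 1 and a 15-fold lower number (1.19 log units; beyond the scatter) from compound 3 to compound 4, 52-fold (1.72 log units) apart, beyond the scatter of two such steps. On the core of compound 3 the change gave a 15-fold lower number from compound 3 to compound 4 (1.19 log units; beyond the scatter), a large strengthening of growth inhibition, whereas the same change weakened growth inhibition on the core of compound 2, and in this series neither the size nor the direction of the step can be taken from one core to the other. With only these two pairs, the data do not show which difference between the cores goes with the reversal, nor how the change would behave on a third core.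

The compounds shown leave open whether the strengthening on the core of compound 3 is particular to the methyl group, or whether an ethyl group or a longer chain on the same oxygen would give a like step. They also leave open what an amine or a carboxylic acid in place of the methoxy group would give on that core.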